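The source may hold more compounds than are shown below. What is called first, only, known or untested is meant among the compounds shown, and "the series" means these compounds.

Compound 1 `CCOC(=O)Cn1ncc2c(Nc3ccc(NS(=O)(=O)c4ccc([N+](=O)[O-])cc4)cc3)ncnc21`: > 64 ug/mL
Compound 2 `CCOC(=O)Cn1ncc2c(Nc3ccc(NS(=O)(=O)c4ccccc4)cc3)ncnc21`: > 100 ug/mL

In a functional assay on cells (Homo sapiens) for inhibition, read by MTT assay, with a stated time of 72 h (a higher number here means a weaker inhibitor, a lower number a stronger inhibitor), compound 1 gives > 64 ug/mL, which is a limit of the assay rather than a number, so compound 1 sits at the limit of > 64 ug/mL in this assay, at which 1 of the 2 values shown sits. Compound 2 gives > 100 ug/mL in this assay, again a limit, at the limit of > 100 ug/mL in this assay, at which 1 of the 2 values shown sits. Going by the values given here, the only measured step, a step that the two limits leave unreadable from compound 1 to compound 2, is hydrogen in place of nitro on an aromatic carbon, and its size cannot be read from two limits. Compound 3 `O=C(O)Cn1ncc2c(Nc3ccc(NS(=O)(=O)c4ccc([N+](=O)[O-])cc4)cc3)ncnc21` differs from compound 1 by hydrogen in place of ethyl on an oxygen next to a carbonyl group. No measured step covers this change, and both measured values are limits, so nothing shown sets a size or direction for it. Compound 3 is therefore expected to give much the same reading, a step that the limit leaves unreadable from compound 1 to compound 3, most likely again reported only as a limit. The estimate for compound 3 in this assay is 80 ug/mL, between 30 ug/mL and 200 ug/mL.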

Compound 3, half-maximal inhibitory concentration: > 100 ug/mL
Compound 3 gave a limit, no number (the forecaster's own chance of this, stated with the estimate: 75%); at least 1.2-fold (0.09 log units) between middle value and limit.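

Compound 1 and compound 3 both give only a limit in this assay, so the step from ethyl to hydrogen on that oxygen cannot be read. The compounds shown leave open whether this change, or the loss of nitro, alters inhibition at all.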